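A few compounds are considered here, and "the series" means these few. Any claim that something is new, unique, unknown or untested is made for them only; others in the source may bear on it.

Measured compounds:
Compound 1 `CS(=O)(=O)c1ccc(C(=O)NCC(=O)N(Cc2ccccc2)Cc2ccccc2)cc1[N+](=O)[O-]` in an assay on isolated protein for inhibition of thyroid hormone receptor alpha (Homo sapiens), read by fluorescence polarization; a higher number here means a weaker inhibitor, a lower number a stronger inhibitor: 1700 nM
Compound 2 `Cc1ccc(N2CCN(C(=O)C3CCN(C(=O)c4ccc(S(C)(=O)=O)c([N+](=O)[O-])c4)CC3)CC2)cc1`: > 60000 nM, a limit of the assay rather than a number
Compound 3 `CN(Cc1cccc(F)c1)C(=O)CNC(=O)c1ccc(S(C)(=O)=O)c([N+](=O)[O-])c1`: > 60000 nM, likewise a limit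

The three compounds share a core carrying a methylsulfonyl group and a nitro group on an aromatic ring. Only compound 1 gives a measured number in this assay. Compound 2 stands at the assay limit, and compound 3 stands at the same limit, so nothing separates these two on the numbers shown; compound 2 cannot be placed relative to compound 3, and only its distance from compound 1 is visible, as a limit rather than a measured gap. This is summed up by the limit of > 60000 nM in this assay, at which 2 of the 3 values shown sit.

Compound 4 `CN1CCN(C(=O)C2CCN(C(=O)c3ccc(S(C)(=O)=O)c([N+](=O)[O-])c3)CC2)CC1` has not yet been measured. It differs from compound 2 in one place: methyl in place of 4-methylphenyl on an amine nitrogen in a ring. Within the data shown here, no measured pair shows the effect of such a change, so the direction of the step cannot be read from the data. Because compound 2 sits at the limit described in the limit of > 60000 nM in this assay, at which 2 of the 3 values shown sit, compound 4 is expected to stay near that limit as well, with a step that the limit leaves unreadable from compound 2 to compound 4, none beyond the scatter. Compound 4 is therefore estimated at 70000 nM, within a range from 20000 nM to 200000 nM, most probably reported again as a limit.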

Compound 4, half-maximal inhibitory concentration: > 60000 nM
Compound 4: only a limit was reported; the forecaster's own chance of this, stated with the estimate: 80%; the middle value is on the limit's open side.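

In this assay compound 4 gives > 60000 nM, a limit of the assay and not a number. Compound 2 also stands at a limit, so no step can be read between compound 2 and compound 4. The compounds shown leave open whether methyl and 4-methylphenyl on this ring nitrogen differ at all in this assay.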